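Benzyl to phenyl on the amide: expected cytotoxicity

The source may hold more compounds than are shown below. What is called first, only, known or untested is meant among the compounds shown, and "the series" means these compounds.

Compound 1, `CC(Sc1nnc(-c2ccncc2)s1)C(=O)NCc1ccccc1Cl`: > 50000 nM
Compound 2, `CC(Sc1nnc(-c2ccncc2)s1)C(=O)NCc1ccc(Cl)cc1`: "not determined" (no result reported)

Two compounds share one core and differ only in the benzyl group that carries the chlorine. In an ADME assay on BHK-21 cells (Mesocricetus auratus) for cytotoxicity, with a stated time of 3 days (on this read-out lower numbers stand for higher toxicity in this test and higher numbers for lower toxicity in this test), compound 1 gives > 50000 nM, which is a limit of the assay rather than a number. For compound 2 no result was reported in this assay ("not determined" (no result reported)). Compound 2 therefore stands without a number of its own. For the measured compounds named here, the one value shown in this assay, (the limit of > 50000 nM in this assay, at which 1 of the 2 values shown sits), belongs to compound 1.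

Compound 3, `CC(Sc1nnc(-c2ccncc2)s1)C(=O)Nc1ccc(Cl)cc1`, differs from compound 2 by 4-chlorophenyl in place of 4-chlorobenzyl on an amide-type nitrogen. Going by the values given here, no step between measured compounds is available, so there is no measured guide to the size of this change. Since compound 1 reaches only (the limit of > 50000 nM in this assay, at which 1 of the 2 values shown sits), the expected step in this assay is none beyond the usual scatter, with the result most likely again a limit. Compound 3 is expected to give 50000 nM in this assay, estimated between 20000 nM and 120000 nM.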

Compound 3, half-maximal cytotoxic concentration: > 50000 nM
Compound 3 gave a limit, no number; the forecaster's own chance of this, stated with the estimate: 70%; the middle value lies on the limit itself.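

Compound 1 and compound 3 each give only a limit in this assay, so no step between them can be read: the limit of > 50000 nM in this assay, at which 2 of the 3 values shown sit.

The compounds shown leave open where either compound's true value lies, and whether 4-chlorophenyl in place of 4-chlorobenzyl changes cytotoxicity at all, with compound 2 standing without a number.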